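Tert-butyl in place of cyclopropyl on the amide nitrogen

The source may report more compounds than this note shows. Statements on the series, on what has been measured and on what is new or still open speak of the compounds shown alone.

The series was examined in an assay on isolated protein for inhibition of sterol O-acyltransferase 1 (Mus musculus), tested at 0.1 uM; on this read-out lower numbers stand for less inhibition and higher numbers for more inhibition at the one concentration tested (going by the name of the read-out). Compound 1 `CCCCCCCCCCCCn1nnc(C(C(=O)Nc2c(OC)ncnc2OC)c2ccccc2)n1` reached 39% in this assay. Among the measured compounds shown here, compound 2 `CCCCCCCCCCCCn1nnc(C(C(=O)NC2CC2)c2ccccc2)n1` gave 10%, which is the lowest of the two numbers measured so far; the only step recorded, a number 29 percentage points lower from compound 1 to compound 2 (beyond the scatter), shows how far the read-out fell when the larger aromatic group on the amide-type nitrogen gave way to cyclopropyl. Compound 3 `CCCCCCCCCCCCn1nnc(C(C(=O)NC(C)(C)C)c2ccccc2)n1` continues at the same place: tert-butyl in place of cyclopropyl on an amide-type nitrogen. For the measured compounds named here, the one measured step bears on this position, but it compared a larger aromatic group with a small alkyl group, whereas cyclopropyl and tert-butyl are both small alkyl groups of nearly equal size. Going by the values given here, no step among the measured compounds distinguishes two such groups. A change in this assay no larger than the scatter is therefore expected, a number 4 percentage points higher from compound 2 to compound 3 (within the scatter), so that compound 3 is estimated at 14% with a range from 0% to 35%.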

Compound 3, a percentage reported as inhibition, at one concentration (the size of the read-out at that concentration, not a potency): 1%
Compound 3: middle estimate off by 13 percentage points, on the high side; the range from low to high includes it.
By their numbers in this assay, from the lowest: compounds 3 and 2 (each within the scatter of the next); then compound 1.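

In this assay the two small alkyl groups on the amide-type nitrogen cannot be told apart, as tert-butyl in place of cyclopropyl gives only a step within the scatter (a number 9 percentage points lower from compound 2 to compound 3 (within the scatter)). The larger aromatic group of compound 1 gives way to tert-butyl with a clear loss (a number 38 percentage points lower from compound 1 to compound 3 (beyond the scatter)), so the earlier drop no longer rests on cyclopropyl alone: two small alkyl groups, one with a ring and one without, now both stand well short of compound 1. No evidence at hand accounts for this result.

Which part of the larger group holds the higher number remains open. A phenyl group on the amide-type nitrogen, or the same aromatic ring without its methoxy groups, would bear on that question.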